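Changing the aryl ketone group: what cytotoxicity to expect

The source may hold more compounds than are shown below. What is called first, only, known or untested is meant among the compounds shown, and "the series" means these compounds.

Measured so far:
compound 1 `COC(=O)c1cc(-c2cccc(NC(=O)c3ccc(/C=C/C(=O)c4cc(OC)c(OC)c(OC)c4)cc3)c2)on1` — > 50 ug/mL
compound 2 `CCOC(=O)c1cc(-c2cccc(NC(=O)c3cccc(C(F)(F)F)c3)c2)on1` — "not determined" (no result reported)

Going by the values given here, two compounds belong to this set, but only one carries a number-like result in an ADME assay on Vero cells (Chlorocebus sabaeus) for cytotoxicity, read by MTT assay, with a stated time of 72 h; a lower number here means that less compound is tolerated, a higher number that more compound is tolerated. For compound 1 the result is a limit rather than a measured number: compound 1 gives > 50 ug/mL, which is the limit of > 50 ug/mL in this assay, at which 1 of the 2 values shown sits. Compound 2, which carries a trifluoromethyl-substituted amide in place of the longer chain, has no result in this assay: "not determined" (no result reported). Among the compounds with values here, with a single limit as the only data point, no step between measured compounds can be drawn, and compound 1 simply stands at the limit.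

Compound 3 `COC(=O)c1cc(-c2cccc(NC(=O)c3ccc(/C=C/C(=O)c4ccc(C)c([N+](=O)[O-])c4)cc3)c2)on1` has not yet been tested. It differs from compound 1 in one place: 4-methyl-3-nitrophenyl in place of 3,4,5-trimethoxyphenyl on a carbonyl carbon. The shared core, the amide and the double-bonded chain leading to the carbonyl stay the same. Since the only anchor is a limit, the expectation for a number no higher from compound 1 to compound 3 (the limit leaves the size open) is no step beyond the scatter. Compound 3 is therefore expected to give 50 ug/mL, with a range from 20 ug/mL to 100 ug/mL, and it may again be reported only as a limit.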

Compound 3, half-maximal cytotoxic concentration: > 80 ug/mL
Compound 3: no number, only a limit; the forecaster's own chance of this, stated with the estimate: 65%; middle value at least 1.6-fold (0.20 log units) away from the limit.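

Going by these compounds alone, compound 1 and compound 3 each carry only a limit in this assay, not a number, and the swap of 3,4,5-trimethoxyphenyl for 4-methyl-3-nitrophenyl gives no step that can be read. On these data alone, the concentration at which either compound harms the cells stays open, and with it whether this swap changes cytotoxicity at all.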